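The compounds below may be only part of what the source reports. "The series", "measured", "known", "first", "only" and "open" are said of these compounds alone.

Compound 2 `CC(C)(C)c1ccc(-c2nc3c(N4CCN(Cc5cn(-c6nc7ccccc7[nH]6)nn5)CC4)cccc3[nH]2)cc1` holds the only plain number shown in a functional assay on cells for antagonist activity at Gonadotropin-releasing hormone receptor (Homo sapiens), read by FLIPR and calcium flux, with a stated time of 15 min (a higher number here means a weaker inhibitor, a lower number a stronger inhibitor), where compound 2 gives 104 nM. Compound 1 `CC(C)(C)c1ccc(-c2nc3c(N4CCN(Cc5cn([C@@H]6O[C@H](CO)[C@@H](O)[C@H](O)[C@H]6O)nn5)CC4)cccc3[nH]2)cc1` gives only a limit of this assay, > 1000 nM. The step of an at least 9.6-fold lower number from compound 1 to compound 2 (0.98 log units; beyond the scatter) shows that the group on this aromatic nitrogen can move the result strongly. Compound 3 `CC(C)(C)c1ccc(-c2nc3c(N4CCN(Cc5cn(-c6ccc(F)cc6)nn5)CC4)cccc3[nH]2)cc1` differs from compound 2 by 4-fluorophenyl in place of 1H-benzimidazol-2-yl on an aromatic nitrogen. Among the compounds with values here, only that one measured step touches this position, so some shift is expected, probably toward a weaker inhibitor. Compound 3 is therefore expected to give 250 nM in this assay, between 80 nM and 900 nM. This expectation means a step of a 2.4-fold higher number from compound 2 to compound 3 (0.38 log units; beyond the scatter).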

Compound 3, inhibition constant: 410 nM
The estimate for compound 3 lay 1.6-fold (0.21 log units) below the measured number; measured number inside the range.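

In this assay, the 4-fluorophenyl group gives a 3.9-fold higher number from compound 2 to compound 3 (0.60 log units; beyond the scatter), so this nitrogen favours 1H-benzimidazol-2-yl over this single aromatic ring, although the change also removes a hydrogen-bond donor and acceptor, and the step cannot separate these differences. Replacing 3,4,5-trihydroxy-6-(hydroxymethyl)oxan-2-yl with 4-fluorophenyl gives an at least 2.4-fold lower number from compound 1 to compound 3 (0.38 log units; beyond the scatter), so a second, unrelated aromatic group also beats the compound 1 group. Compound 1 gives only a limit, so the full size of that step stays unknown: the limit of > 1000 nM in this assay, at which 1 of the 3 values shown sits.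

Still open, from the compounds shown here alone, is how plain phenyl, or a phenyl carrying a carboxylic acid or an amine, would read on this nitrogen.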